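From methoxy to carbamoyl on a shared core

This account rests on a few compounds, and the source may have more. Where it says the series, first, only, none or still open, it means among the compounds named here.

Compound 1 `Cc1ccc(C(O)(c2ccc(Cl)cc2)c2cccnc2)cc1` – 61000 nM
Compound 2 `OC(c1ccc(Cl)cc1)(c1ccncn1)c1ccccc1Cl` – > 100000 nM (a limit)
Compound 3 `COc1cccc(C(O)(c2ccc(Cl)cc2)c2cccnc2)c1` – 85600 nM

In an ADME assay on L6 cells (Rattus norvegicus) for cytotoxicity, read by resazurin assay, with a stated time of 72 h (on this read-out lower numbers stand for stronger inhibition and higher numbers for weaker inhibition), compound 3 (85600 nM) lies within the scatter of compound 1 (61000 nM). Compound 2 gives only a limit (> 100000 nM).

Compound 4 `NC(=O)c1cccc(C(O)(c2ccc(Cl)cc2)c2cccnc2)c1` has carbamoyl in place of methoxy on an aromatic carbon, meta to a large group carbamoyl in place of methoxy on an aromatic carbon and otherwise keeps the core of compound 3. Among the compounds with values here, no measured pair shows a comparable change, so little beyond the scatter is expected in this assay and a report of only a limit remains possible. The expected change is a 1.1-fold higher number from compound 3 to compound 4 (0.02 log units; within the scatter) in this read-out. For compound 4 the estimated value is 90000 nM (expected range 45000 nM to 120000 nM).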

Compound 4, half-maximal inhibitory concentration: > 100000 nM
Compound 4 was reported as a limit; the forecaster's own chance of this, stated with the estimate: 45%; middle value at least 1.1-fold (0.04 log units) away from the limit.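

In this assay, carbamoyl in place of methoxy on an aromatic carbon, meta to a large group, gives an at least 1.1-fold higher number from compound 3 to compound 4 (0.06 log units; that floor lies within the scatter). At this place, a group carrying a hydrogen-bond donor therefore brings no lower number, although the floor of the step does not separate carbamoyl from methoxy. Compound 4 gives only a limit, as compound 2 does: the limit of > 100000 nM in this assay, at which 2 of the 4 values shown sit.

On these data alone, how far compound 4 really lies from compound 3 stays open. So does whether an amine or a carboxylic acid at this place would give a lower number.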